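The source may hold more compounds than are shown below. What is called first, only, known or untested is meant among the compounds shown, and "the series" means these compounds.

Measured in a functional assay (B cells) with Mus musculus as the target; a higher number here means that more compound is needed for the effect, a lower number that less compound is needed:
Compound 1, `CN(C)CCCn1c(=O)n(C2OC(CO)[C@@H](O)[C@H]2O)c2nc(N)nc(O)c21`, gives 194 uM.
Compound 2, `C=CCn1c(=O)n(C2C[C@H](O)C(CO)O2)c2nc(N)nc(O)c21`, gives 30 uM.
Compound 3, `C=CCn1c(=[Se])n(C2OC(CO)[C@@H](O)[C@H]2O)c2nc(N)nc(O)c21`, gives 15 uM.

Compound 1 has the highest number of the three, so it needs the most compound for the effect, and its distance to compound 2 and to compound 3 lies beyond the usual scatter. Compound 4, `NCC(O)Cn1c(=O)n(C2OC(CO)[C@@H](O)[C@H]2O)c2nc(N)nc(O)c21`, has not been measured. It keeps the shared core and the sugar of compound 1 and differs only in the side chain on the ring nitrogen: 2-amino-1-hydroxyethyl in place of 2-(dimethylamino)ethyl on a saturated chain carbon bound to an aromatic nitrogen. Within the data shown here, no measured pair shows the effect of this kind of change, so the expectation rests on compound 1 alone. The step from compound 1 is expected to be small, a 1.5-fold lower number from compound 1 to compound 4 (0.17 log units; within the scatter), and may not reach beyond the scatter. Compound 4 is therefore estimated at 130 uM, within a range from 40 uM to 450 uM.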

Compound 4, concentration for half-maximal effect: 28 uM
Compound 4: middle estimate off by 4.6-fold (0.67 log units), on the high side, and the stated range ends above it.
By their numbers in this assay, from the lowest: compounds 3, 4 and 2 (each within the scatter of the next); then compound 1.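

The side chain is not a silent spot: with the sugar and the shared core unchanged, 2-amino-1-hydroxyethyl in place of 2-(dimethylamino)ethyl gives a 6.9-fold lower number from compound 1 to compound 4 (0.84 log units; beyond the scatter) in this assay. The earlier compounds shown here offered no pair differing in one place, so they could not show this. Nothing available explains the step.

The change swaps the dimethylamino end for an amine and adds a hydroxyl at once, and the compounds shown do not separate the two. As far as these compounds go, how a side chain with a carboxylic acid or a longer chain would read also stays open.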